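A Methyl for a Methoxy on the Aryl Group

The source may hold more compounds than are shown below. What is called first, only, known or untested is meant among the compounds shown, and "the series" means these compounds.

Of the compounds shown here, three sharing one fused core have been measured so far. In an assay on CHO cells for displacement of a labelled ligand from adenosine receptor A3 (Homo sapiens), read by scintillation counting, with a stated time of 3 h (a lower number here means a stronger inhibitor, a higher number a weaker inhibitor), compound 1 `COc1ccc(-c2nc3c(NC4CCCC4)ncnc3n2C)cc1` gives 1850 nM. Compound 2 `CCn1c(-c2ccccc2)nc2c(NC3CCOC3)ncnc21` gives 1660 nM in this assay, and compound 3 `CCCn1c(-c2ccccc2)nc2c(NC3CCCCC3)ncnc21` gives 2360 nM. The three numbers lie close together: compound 1 stands between the other two, and its gaps to compound 2 and to compound 3 both fall within the usual scatter of repeated measurements, so no order among them can be read from these data.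

Compound 4 `Cc1ccccc1-c1nc2c(NC3CCCC3)ncnc2n1C` has not been measured in this assay. It differs from compound 1 in one place only: 2-methylphenyl in place of 4-methoxyphenyl on an aromatic carbon. Going by the values given here, no measured pair in this set shows what such an exchange does, since the three measured compounds differ from one another in several places at once.

With nothing in the data to point one way or the other, the expected step from compound 1 to compound 4, a 1.4-fold higher number from compound 1 to compound 4 (0.13 log units; within the scatter), is taken to be small and not beyond the scatter. Compound 4 is therefore estimated at 2500 nM in this assay, with a range from 700 nM to 9000 nM to cover the uncertainty of an untested change.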

Compound 4, inhibition constant: 3000 nM
For compound 4 the middle estimate is 1.2-fold (0.08 log units) below the measured one; low and high end bracket the measured number.
By their numbers in this assay, from the lowest: compounds 2, 1, 3 and 4 (each within the scatter of the next).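

In this assay, going by these compounds alone, the exchange of 4-methoxyphenyl for 2-methylphenyl gives the first step in this set that changes one place alone: a 1.6-fold higher number from compound 1 to compound 4 (0.21 log units; within the scatter). At this aromatic carbon, next to the ring atom that bears a methyl group, a group with a hydrogen-bond acceptor thus gives way to one without, and the two compounds stay within the scatter of each other, so this single exchange shows no measurable change in the number. Nothing measured here bears on why the step is this size.

Because the exchange alters both the substituent and where it stands on the phenyl ring, these two compounds cannot separate those two changes, and the steps to compound 2 and compound 3, which differ from them in several places at once, cannot be read. From the compounds shown here alone, it remains open what a carboxylic acid or an amine on the aryl group would do at this place, and whether any group here can move the number beyond the scatter.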